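From Hydroxy to Methoxy at an Assay Limit

The compounds below may be only part of what the source reports. "The series", "measured", "known", "first", "only" and "open" are said of these compounds alone.

In a functional assay on DU-145 cells (Homo sapiens) for cytotoxicity, read by MTT assay, with a stated time of 72 h (a higher number here means a weaker inhibitor of growth, a lower number a stronger inhibitor of growth), compound 2 `N#C/C(=C/c1ccc(O)cc1)C(=O)c1ccc[nH]1` gives < 10000 nM, which is a limit and not a number. Compound 1 `N#C/C(=C/c1ccc([N+](=O)[O-])cc1)C(=O)c1ccc[nH]1` gives < 10000 nM, also a limit. The data stop at the limit of < 10000 nM in this assay, at which 2 of the 2 values shown sit. Compound 3 `COc1ccc(/C=C(/C#N)C(=O)c2ccc[nH]2)cc1` has methyl in place of hydrogen on an oxygen on an aromatic ring, hydroxy to methoxy (methyl in place of hydrogen on an oxygen on an aromatic ring). For the measured compounds named here, the only measured step is a step that the two limits leave unreadable from compound 1 to compound 2, so it offers no size to carry over. No step beyond the scatter, in either direction, is therefore expected in this assay. The estimated step is a step that the limit leaves unreadable from compound 2 to compound 3. For compound 3 the expected value is 3000 nM, with an estimated range from 500 nM to 10000 nM.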

Compound 3, concentration for 50% growth inhibition: < 10000 nM
Compound 3 ended at the assay's limit; the forecaster's own chance of this, stated with the estimate: 60%; the middle value lies beyond the limit too.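

No step between compound 1, compound 2 and compound 3 can be read in this assay, as all three stand at a limit: the limit of < 10000 nM in this assay, at which 3 of the 3 values shown sit.

From the compounds shown here alone, how strongly compound 1, compound 2 and compound 3 each inhibit growth remains open, as does whether their differing groups change it.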